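Notes on a nitro-for-methoxy exchange

The source may hold more compounds than are shown below. What is called first, only, known or untested is meant among the compounds shown, and "the series" means these compounds.

Measured so far:
compound 1, `N#CC1=C(N)N(c2ccc(S(N)(=O)=O)cc2)C2=C(CCCC2)C1/C=C/c1ccccc1`, 90%
compound 2, `COc1ccc(C2C(C#N)=C(N)N(c3ccc(S(N)(=O)=O)cc3)C3=C2CCCC3)cc1`, 100%

In a functional assay on Ehrlich cells (Mus musculus) for cytotoxicity, read by trypan blue exclusion, with a stated time of 2 h, tested at 50 ug/mL (a higher number here means a stronger effect of the compound at the concentration tested, a lower number a weaker effect), compound 2 gives 100% and stands at the top of the two numbers shown, though the gap to compound 1, which gives 90%, is within the scatter. Among the compounds with values here, the single step between them, a number 10 percentage points higher from compound 1 to compound 2 (within the scatter), is therefore no evidence of a real change on exchanging the group on the saturated ring carbon. Compound 3, `N#CC1=C(N)N(c2ccc(S(N)(=O)=O)cc2)C2=C(CCCC2)C1c1ccc([N+](=O)[O-])cc1`, keeps the core of compound 2 and alters only (nitro in place of methoxy on an aromatic carbon). Within the data shown here, no measured pair separates nitro from methoxy, so the only step that bears on this exchange is the one between compound 1 and compound 2, and that one lies within the scatter. With compound 2 already at the top of the read-out, no change beyond the scatter is expected in this assay for compound 3, whose step is estimated as a number 5 percentage points lower from compound 2 to compound 3 (within the scatter). Compound 3 is expected to give 95%, with a range of 80% to 100%.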

Compound 3, a percentage reported as activity, at one concentration (the size of the read-out at that concentration, not a potency): 10%
Compound 3: the middle estimate sits 85 percentage points above what was measured; measured number outside the range, below it.
By their numbers in this assay, from the lowest: compound 3; then compounds 1 and 2 (each within the scatter of the next).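

In this assay, within the data shown here, the exchange on an aromatic carbon, para to a large group, gives the first step that lies beyond the scatter, with nitro in place of methoxy (a number 90 percentage points lower from compound 2 to compound 3 (beyond the scatter)). The group on the saturated ring carbon therefore cannot be treated as freely exchangeable: the earlier step between 2-phenylethenyl and 4-methoxyphenyl (a number 10 percentage points higher from compound 1 to compound 2 (within the scatter)) showed no real change, whereas 4-nitrophenyl in place of 2-phenylethenyl gives a large one (a number 80 percentage points lower from compound 1 to compound 3 (beyond the scatter)), and among these three compounds only compound 3 stands apart. Nothing measured on these compounds accounts for the loss of effect.

Open, from the compounds shown here alone, is whether the loss belongs to nitro alone or extends to other groups at this place on the aromatic ring, such as an amine, a carboxylic acid, a chlorine atom or an unsubstituted phenyl ring. Also open, going by these compounds, is how compound 1 and compound 2 compare in potency, since the read-out at a single concentration gives only the size of the effect at that concentration.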